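A few compounds are considered here, and "the series" means these few. Any claim that something is new, unique, unknown or untested is made for them only; others in the source may bear on it.

Measured so far:
Compound 1, `CSc1ccc(/C=C(/SCc2ccc(C)cc2)C(=O)c2ccc(Cl)cc2)cc1` — 25000 nM
Compound 2, `Cc1ccc(CS/C(=C/c2sccc2C)C(=O)c2ccc(Cl)cc2)cc1` — 10000 nM

In a functional assay on DU-145 cells (Homo sapiens) for inhibition, read by trypan blue exclusion, with a stated time of 96 h (a higher number here means a weaker inhibitor of growth, a lower number a stronger inhibitor of growth), compound 1 gives 25000 nM and stands highest of the two numbers recorded; its nearest neighbour is compound 2, reached by a 2.5-fold lower number from compound 1 to compound 2 (0.40 log units; beyond the scatter), a modest step that lies beyond the scatter. Compound 3, `CSc1ccc(/C=C(/SCc2ccc(Cl)cc2)C(=O)c2ccc(Cl)cc2)cc1`, differs from compound 1 by chloro in place of methyl on an aromatic carbon, which read one bond further out is 4-methylbenzyl to 4-chlorobenzyl on the sulfanyl arm. Going by the values given here, no measured step bears on this part of the molecule: the one step known, from compound 1 to compound 2, alters the aryl on the double-bonded chain carbon and leaves the benzyl untouched. With nothing to go on but a single-atom swap on an aromatic carbon, the author expects compound 3 to show no step beyond the scatter, a 1.3-fold lower number from compound 1 to compound 3 (0.10 log units; within the scatter). Compound 3 is therefore estimated at 20000 nM, with a range from 8000 nM to 50000 nM.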

Compound 3, concentration for 50% growth inhibition: 25000 nM
For compound 3 the middle estimate is 1.3-fold (0.10 log units) below the measured one; measured number inside the range.
By their numbers in this assay, from the lowest: compound 2; then compounds 1 and 3 (each within the scatter of the next).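

In this assay, going by these compounds alone, the change from 4-methylbenzyl to 4-chlorobenzyl on the sulfanyl arm gives no change at the digits printed from compound 1 to compound 3 (within the scatter) and is the first reading at this end of the molecule, since the earlier step altered only the aryl on the double-bonded chain carbon. At this place, para to a large group, chloro in place of methyl on an aromatic carbon leaves the number where it stood, so this swap does not separate the two groups here. Nothing measured is at hand that would account for this result.

The compounds shown leave open whether another group on this aromatic carbon, such as an amine or a carboxylic acid, would move the number. They also leave open whether the same swap would read the same in compound 2, which carries 3-methylthiophen-2-yl on the double-bonded chain carbon.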